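This account rests on a few compounds, and the source may have more. Where it says the series, first, only, none or still open, it means among the compounds named here.

Measured in a functional assay on DU-145 cells (Homo sapiens) for antiproliferative activity, read by MTT assay, with a stated time of 72 h; on this read-out lower numbers stand for stronger inhibition and higher numbers for weaker inhibition:
- Compound 1 `O=C1OCC[C@@H]1NC(=S)SCCOc1ccc([N+](=O)[O-])cc1`: 31000 nM
- Compound 2 `O=C(COc1ccc(C(=O)/C=C/c2ccc(F)cc2)cc1)N[C@H]1CCOC1=O`: 18800 nM
- Compound 3 `CC(C)c1ccc(NCC(=O)N[C@H]2CCOC2=O)cc1`: > 64000 nM (a limit, not a number)

Compound 2, at 18800 nM, lies within the usual scatter of compound 1, at 31000 nM, so these two cannot be told apart. For compound 3, this assay reports only the limit > 64000 nM.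

Compound 4 `O=C(COc1ccc(C(=O)/C=C/c2cccc(F)c2)cc1)N[C@H]1CCOC1=O` differs from compound 2 in one place: 3-fluorophenyl in place of 4-fluorophenyl on a double-bonded chain carbon bound to a double-bonded chain carbon. It carries 3-fluorophenyl in place of 4-fluorophenyl, with the same atoms joined differently.

Within the data shown here, no measured pair shows a change of this kind, so no shift in either direction is expected beyond the scatter in this assay. The expected change is a 1.0-fold lower number from compound 2 to compound 4 (0.02 log units; within the scatter). Compound 4 is estimated at 18000 nM, with an expected range of 8000 nM to 40000 nM.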

Compound 4, half-maximal inhibitory concentration: 17200 nM
Compound 4: the middle estimate sits 1.0-fold (0.02 log units) above what was measured; the range from low to high includes it.
By their numbers in this assay, from the lowest: compounds 4, 2 and 1 (each within the scatter of the next). At a limit, above all of these: compound 3.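

Compounds 1, 2 and 3 differ from one another in more than one place, so they could not show what a single change does. Here, 3-fluorophenyl in place of 4-fluorophenyl on a double-bonded chain carbon gives a 1.1-fold lower number from compound 2 to compound 4 (0.04 log units; within the scatter) in this assay, so the two arrangements of the fluorine cannot be told apart. Nothing shown bears on why the number holds.

Still open, going by these compounds, is whether a different group at this place, such as an amine or a carboxylic acid on the aromatic ring, would move the number beyond the scatter.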